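Same Ring Swap on a Second Core: What to Expect

The source may report more compounds than this note shows. Statements on the series, on what has been measured and on what is new or still open speak of the compounds shown alone.

Measured compounds:
- compound 1, `O=C(O)CCC/C=C1\CC2C[C@@H](O)[C@H](/C=C/[C@@H](O)C3COc4ccccc4O3)C2C1`: 0.0045 mg/kg
- compound 2, `O=C(O)CCC/C=C1\CC2C[C@@H](O)[C@H](/C=C/[C@@H](O)C3Cc4ccccc4C3)C2C1`: 0.0562 mg/kg
- compound 3, `O=C(O)COC/C=C1\CC2C[C@@H](O)[C@H](/C=C/[C@@H](O)C3COc4ccccc4O3)C2C1`: 0.113 mg/kg

In a functional assay on the whole organism (stomach) for inhibition, with Rattus norvegicus as the target (on this read-out higher numbers stand for an effect only at larger amounts of compound and lower numbers for an effect already at smaller amounts), compound 1 gives 0.0045 mg/kg. Compound 2 differs from compound 1 in one place: 2,3-dihydro-1H-inden-2-yl in place of 2,3-dihydro-1,4-benzodioxin-2-yl on a saturated chain carbon bound to a double-bonded chain carbon and an oxygen on a saturated carbon. That single swap moved the read-out as a 12-fold higher number from compound 1 to compound 2 (1.10 log units; beyond the scatter), so the indane-type end group needs a clearly larger dose than the benzodioxin-type one on this core.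

Compound 3 carries the same benzodioxin-type end group as compound 1 but a different core: carboxymethoxy in place of 2-carboxyethyl on a saturated chain carbon bound to a double-bonded chain carbon. That change also costs potency, a 25-fold higher number from compound 1 to compound 3 (1.40 log units; beyond the scatter), and compound 3 gives 0.113 mg/kg in this assay. Compound 2 and compound 3 sit close together, within the usual scatter, so no order between them can be read.

Compound 4, `O=C(O)COC/C=C1\CC2C[C@@H](O)[C@H](/C=C/[C@@H](O)C3Cc4ccccc4C3)C2C1`, has not yet been measured. It stands to compound 3 exactly as compound 2 stands to compound 1: 2,3-dihydro-1H-inden-2-yl in place of 2,3-dihydro-1,4-benzodioxin-2-yl on a saturated chain carbon bound to a double-bonded chain carbon and an oxygen on a saturated carbon. The place of the change is the same in both pairs, so this is the same change made on a second core. If the swap behaves as it did on the first core, compound 4 is expected to need a dose that is higher than compound 3 by about an 8.8-fold higher number from compound 3 to compound 4 (0.95 log units; beyond the scatter), a step expected to be of similar size to the earlier one, because a 12-fold higher number from compound 1 to compound 2 (1.10 log units; beyond the scatter) is the only measure of this change available. Compound 4 is therefore estimated at 1 mg/kg, with a plausible range from 0.3 mg/kg to 4 mg/kg. Whether two changes that each cost potency add up fully on one molecule is not shown by these three compounds, which is why the range is kept wide.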

Compound 4, dose for half-maximal effect: 0.0675 mg/kg
Compound 4: the middle estimate sits 15-fold (1.17 log units) above what was measured; measured number below the stated range.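

In this assay, the swap to 2,3-dihydro-1H-inden-2-yl on the second core gives a 1.7-fold lower number from compound 3 to compound 4 (0.22 log units; within the scatter), so the large step seen on the first core did not carry over: the same change on two cores in this assay, a 12-fold higher number (1.10 log units; beyond the scatter) from compound 1 to compound 2 and a 1.7-fold lower number (0.22 log units; within the scatter) from compound 3 to compound 4, 21-fold (1.32 log units) apart, beyond the scatter of two such steps The other change, carboxymethoxy in place of 2-carboxyethyl, behaves the same way, giving a 1.2-fold higher number from compound 2 to compound 4 (0.08 log units; within the scatter) when the 2,3-dihydro-1H-inden-2-yl end group is present, which is far from its size when the 2,3-dihydro-1,4-benzodioxin-2-yl end group is present: the same change on two cores in this assay, a 25-fold higher number (1.40 log units; beyond the scatter) from compound 1 to compound 3 and a 1.2-fold higher number (0.08 log units; within the scatter) from compound 2 to compound 4, 21-fold (1.32 log units) apart, beyond the scatter of two such steps So in these four compounds the effect of each change depends on what the rest of the molecule carries, and a step measured on one core was a poor guide to the same step on the other, but a single set of four compounds shows neither why this happens nor whether it holds for any other pair of groups.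

Going by these compounds, it remains open whether a third end group in the same place, such as a cyclohexyl or a plain phenyl group, would also show a large step on the first core and a small one on the second. On these data alone, it is equally open whether a sulfur atom in place of the chain oxygen of carboxymethoxy would give the same dependence.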